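Trifluoromethyl on the phenyl ring of compound 1

The source may hold more compounds than are shown below. What is called first, only, known or untested is meant among the compounds shown, and "the series" means these compounds.

Compound 1 `O=C(O)CCCSCCN1C(=O)SC[C@@H]1/C=C/[C@@H](O)Cc1ccccc1` gives 3.5% in an in vivo ADME assay on the whole organism for pharmacokinetics, with Rattus norvegicus as the target, at a dose of 1 mg/kg by the oral route; a higher number here means that a larger share of the oral dose reaches the circulation, a lower number that a smaller share of the oral dose reaches the circulation. Among the compounds with values here, compound 2 `Cc1cccc(C[C@H](O)/C=C/[C@H]2CCC(=S)N2CCSCCCC(=O)O)c1` gives 9.8% in this assay, and the two numbers lie within the scatter of each other; no step between measured compounds is known. Compound 3 `O=C(O)CCCSCCN1C(=O)SC[C@@H]1/C=C/[C@@H](O)Cc1cccc(C(F)(F)F)c1` differs from compound 1 by trifluoromethyl in place of hydrogen on an aromatic carbon. Within the data shown here, no measured pair shows this change, so no step beyond the scatter is expected in either direction. For compound 3 the estimate is 6%, with a range from 1.5% to 20%. The expected step is a number 2.5 percentage points higher from compound 1 to compound 3 (within the scatter).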

Compound 3, oral bioavailability: 5.5%
For compound 3 the middle estimate is 0.5 percentage points above the measured one; measured number inside the range.
By their numbers in this assay, from the lowest: compounds 1, 3 and 2 (each within the scatter of the next).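

Replacing hydrogen with trifluoromethyl on this aromatic carbon gives, in this assay, a number 2 percentage points higher from compound 1 to compound 3 (within the scatter). Within the data shown here, this pair is the first direct reading of the change, and it shows no step that can be separated from the scatter. No available measurement explains this result.

As far as these compounds go, it remains open whether an amine or a nitrile on the same aromatic carbon would give a step beyond the scatter. From the compounds shown here alone, the effect of trifluoromethyl elsewhere on this ring also remains open.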